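This account rests on a few compounds, and the source may have more. Where it says the series, first, only, none or still open, it means among the compounds named here.

Working notes on the series. Within the data shown here, compound 2 `CC(C)COc1cc(C(F)(F)F)ccc1CNC(=O)C(C)c1ccc(NS(C)(=O)=O)c(F)c1` gives 0.8 nM in an assay on CHO cells for antagonist activity at transient receptor potential cation channel subfamily V member 1 (Homo sapiens), read by FLIPR (a lower number here means a stronger inhibitor, a higher number a weaker inhibitor), and stands lowest of the two numbers so far, while compound 1 `CC(C(=O)NCc1ccc(C(F)(F)F)cc1N1CCC(Cc2ccccc2)CC1)c1ccc(NS(C)(=O)=O)c(F)c1` gives 1.4 nM in this assay, a gap that lies within the scatter. The next compound 3 `CC(C(=O)NCc1ccc(C(F)(F)F)cc1SCc1ccco1)c1ccc(NS(C)(=O)=O)c(F)c1` awaits measurement. The change from compound 2 is ((furan-2-yl)methyl)sulfanyl in place of isobutoxy on an aromatic carbon. Among the measured compounds shown here, no step between measured compounds is available, so for the step from compound 2 to compound 3 only a small shift in this assay is expected, in either direction and likely not beyond the scatter, as compound 1 with 1.4 nM shows that a large group at this position is tolerated. Compound 3 is therefore estimated at 1.5 nM, within 0.5 nM to 5 nM, an expected step of a 1.9-fold higher number from compound 2 to compound 3 (0.27 log units; within the scatter).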

Compound 3, inhibition constant: 3.2 nM
Estimate against measurement, compound 3: 2.1-fold (0.33 log units) below, and the stated range covers the measured number.
By their numbers in this assay, from the lowest: compounds 2 and 1 (each within the scatter of the next); then compound 3.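

In this assay, among these compounds, ((furan-2-yl)methyl)sulfanyl in place of isobutoxy gives a 4.0-fold higher number from compound 2 to compound 3 (0.60 log units; beyond the scatter), the only step available. This aromatic carbon therefore responds to the group it carries, although the step is modest. No measurement on hand accounts for this step. The compounds shown leave open whether the sulfur link or the furan ring carries the step, since both enter together. A (furan-2-yl)methoxy group, with oxygen as the link, or a benzylsulfanyl group, with a benzene ring in place of furan, would separate the two.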